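Swapping a Pyridine for a Phenyl on the Sulfur

This account rests on a few compounds, and the source may have more. Where it says the series, first, only, none or still open, it means among the compounds named here.

Compound 1 `O=C(CSc1ccccc1)N1N=C(c2cc3ccccc3oc2=O)C[C@@H]1c1ccccc1` gives 22800 nM
Compound 2 `CC1=NN(C(=O)CSc2ccccn2)[C@@H](c2cc(Br)cc(Br)c2O)C1` gives 12300 nM

Both numbers come from a functional assay on MGC-803 cells (Homo sapiens) for cytotoxicity, read by MTT assay, with a stated time of 48 h; a lower number here means a stronger inhibitor, a higher number a weaker inhibitor. Compound 2 has the lower of the two, yet its gap to compound 1 lies within the usual scatter, so the two cannot be told apart. Compound 3 `CC1=NN(C(=O)CSc2ccccc2)[C@@H](c2cc(Br)cc(Br)c2O)C1` differs from compound 2 in one place: phenyl in place of pyridin-2-yl on a sulfur. Within the data shown here, no measured pair shows this change alone, and compound 1, which carries phenylsulfanyl too, differs from compound 2 elsewhere as well. The step of a 1.0-fold lower number from compound 2 to compound 3 (0.01 log units; within the scatter) is expected to stay within the scatter, in no clear direction. Compound 3 is therefore estimated at 12000 nM, with a range from 5000 nM to 30000 nM.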

Compound 3, half-maximal inhibitory concentration: 12700 nM
Beside the measured number, compound 3's estimate is 1.1-fold (0.02 log units) below it; low and high end bracket the measured number.
By their numbers in this assay, from the lowest: compounds 2, 3 and 1 (each within the scatter of the next).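

Among these compounds, the step of a 1.0-fold higher number from compound 2 to compound 3 (0.01 log units; within the scatter) in this assay is the first direct reading of this change, with the rest of the molecule held the same. Replacing pyridin-2-yl with phenyl takes away the ring nitrogen, a hydrogen-bond acceptor, with no difference that can be told from scatter. No supporting measurement bears on why the two compounds read alike.

Both groups shown on this sulfur are six-membered aromatic rings. As far as these compounds go, what a longer chain or a carboxylic acid would give at this position stays open.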